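Mouse Microsomal Half-Life After Replacing a Ring on the Carbonyl

The source may report more compounds than this note shows. Statements on the series, on what has been measured and on what is new or still open speak of the compounds shown alone.

Compound 1 `CC1(C(=O)NCCSc2nonc2/C(=N/O)Nc2ccc(F)c(C(F)F)c2)CCN1`: 0.268 h
Compound 2 `N#Cc1cccc(N/C(=N\O)c2nonc2SCCNC(=O)CS(N)(=O)=O)c1`: > 3 h (a limit)

Among the measured compounds shown here, in an ADME assay on microsomes from liver (Mus musculus) for metabolic stability (a higher number here means that the compound lasts longer, a lower number that the compound disappears faster), compound 1 gives 0.268 h, the only exact number available so far. Compound 2 stands at > 3 h, which is a limit of the assay. Compound 3 `CC(C)(O)CC(=O)NCCSc1nonc1/C(=N/O)Nc1ccc(F)c(C(F)F)c1` keeps the core of compound 1 and differs in one group on the carbonyl carbon: a group of 5 heavy atoms (4 carbon, 1 oxygen; no ring) in place of a group of 5 heavy atoms (4 carbon, 1 nitrogen; one four-membered non-aromatic ring with 1 hetero atom), on a carbonyl carbon. A 2-hydroxy-2-methylpropyl group with no ring thus replaces the group carrying the four-membered non-aromatic ring. For the measured compounds named here, no pair of measured compounds shows the size of such a swap, so only a modest upward step in this assay is expected, and it may stay within the scatter. The expected step is a 1.9-fold higher number from compound 1 to compound 3 (0.27 log units; within the scatter). Compound 3 is expected at 0.5 h, with an estimated range of 0.2 h to 1.5 h.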

Compound 3, half-life: 0.175 h
Compound 3: middle estimate off by 2.9-fold (0.46 log units), on the high side; measured number below the stated range.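

In this assay, placing 2-hydroxy-2-methylpropyl on the carbonyl carbon in place of the group carrying the four-membered non-aromatic ring gives a 1.5-fold lower number from compound 1 to compound 3 (0.19 log units; within the scatter). Among the compounds shown here, this is the first step read at this position, and it shows that the open chain, with the same count of hydrogen-bond donors and acceptors and no net charge, leaves compound 3 indistinguishable from compound 1 in this assay. Nothing shown accounts for this result. The compounds shown leave open whether a carboxylic acid, an amine or a longer chain on this carbonyl carbon would give a step beyond the scatter. Compound 2 differs from compound 1 in more than one place, and nothing shown ties any one part of its structure to its value. Compound 2 gives > 3 h, which is a limit of the assay.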